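The source may report more compounds than this note shows. Statements on the series, on what has been measured and on what is new or still open speak of the compounds shown alone.

Measured so far in an ADME assay on RAW264.7 cells (Mus musculus) for cytotoxicity, read by MTT assay, with a stated time of 24 h, in the presence of a further agent that is not named here; on this read-out lower numbers stand for stronger inhibition and higher numbers for weaker inhibition:
compound 1 `CCOc1ccc(C(O)C2OC(=O)c3c(OC)cc(OC)cc32)cc1` — compound 1 gives > 40000 nM, which is a limit of the assay and not a number.
compound 2 `COc1cc(OC)c2c(c1)C(C(O)c1ccc(OCc3ccc(F)cc3)cc1)OC2=O` — compound 2 gives > 40000 nM, again a limit only.

Compound 1 stands at the limit of this assay, and every value shown so far sits at that same place (the limit of > 40000 nM in this assay, at which 2 of the 2 values shown sit). For the measured compounds named here, the one measured step, a step that the two limits leave unreadable from compound 1 to compound 2, cannot be read for size or direction, since both of its ends are limits.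

Compound 3 `COc1cc(OC)c2c(c1)C(C(O)c1ccc(OCc3ccc(OC(F)F)cc3)cc1)OC2=O` is not yet measured in this assay. Its change from compound 1 is 4-(difluoromethoxy)phenyl in place of methyl on a saturated chain carbon bound to an oxygen on an aromatic ring. The step from compound 1 to compound 2 is the only one that bears on this change: it exchanges the same methyl for a substituted phenyl at the same place, and the read-out stayed at the limit at both ends. Nothing in those two values points to any movement within the measured range. The expectation for compound 3 is therefore that the read-out again remains at the limit, with the step that the limit leaves unreadable from compound 1 to compound 3 expected to stay unreadable. Compound 3 is estimated at 70000 nM, with a range from 30000 nM to 250000 nM.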

Compound 3, half-maximal inhibitory concentration: > 40000 nM
Compound 3 ended at the assay's limit; the forecaster's own chance of this, stated with the estimate: 85%; the middle value does not contradict the limit.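

In this assay, no new step can be read: the steps linking compound 3 to compound 1 and compound 2 stay unreadable, since all three compounds stand at a limit and not at a number: the limit of > 40000 nM in this assay, at which 3 of the 3 values shown sit. The compounds shown leave open whether any change at this place on the shared core would bring the read-out within the measured range.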